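This account rests on a few compounds, and the source may have more. Where it says the series, first, only, none or still open, it means among the compounds named here.

Measured in a functional assay on MKN-45 cells (Homo sapiens) for antiproliferative activity, with a stated time of 72 h; on this read-out higher numbers stand for weaker inhibition and lower numbers for stronger inhibition:
- compound 1 `Cn1cc(-c2ccc(NC(=O)c3cn(CC4CCOCC4)cc(-c4ccc(F)cc4)c3=O)c(F)c2)c2c(N)ncnc21`: 210 nM
- compound 2 `Cn1cc(-c2cc(F)c(NC(=O)c3cn(CC4CCOCC4)cc(-c4ccc(F)cc4)c3=O)cc2F)c2c(N)ncnc21`: 53.7 nM

Compound 2, at 53.7 nM, has the lower of the two numbers in this assay. Compound 3 `Cn1cc(-c2ccc(NC(=O)c3cn(CC4CCOCC4)cc(-c4ccc(F)cc4)c3=O)cc2F)c2c(N)ncnc21` has hydrogen in place of fluoro on an aromatic carbon of compound 2: hydrogen in place of fluoro on an aromatic carbon.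

Going by the values given here, only one measured step bears on this change, and only indirectly. a 3.9-fold lower number from compound 1 to compound 2 (0.59 log units; beyond the scatter) is a modest step that comes with a gain of fluoro at a different carbon of the same ring. Among the compounds with values here, no measured step shows the loss of the fluoro at this carbon. A rise of similar or smaller size is therefore expected in this assay, and it may not clear the scatter. The expected step is a 2.0-fold higher number from compound 2 to compound 3 (0.31 log units; beyond the scatter). For compound 3 the estimated value is 110 nM, with an expected range of 35 nM to 340 nM.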

Compound 3, half-maximal inhibitory concentration: 93.7 nM
The estimate for compound 3 lay 1.2-fold (0.07 log units) above the measured number, and the stated range covers the measured number.
By their numbers in this assay, from the lowest: compounds 2 and 3 (each within the scatter of the next); then compound 1.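

In this assay, hydrogen in place of fluoro at this carbon, ortho to a large group and meta to a large group, gives a 1.7-fold higher number from compound 2 to compound 3 (0.24 log units; within the scatter), so this fluoro has no readable effect on the number between this pair. The other fluoro of compound 2 behaves differently: its gain gives a 3.9-fold lower number from compound 1 to compound 2 (0.59 log units; beyond the scatter), so the two fluoro positions on this ring do not read alike in this assay. No available evidence bears on the reason for this difference.

From the compounds shown here alone, whether a chloro, a methoxy or an amine at this carbon would stay within the scatter of fluoro and hydrogen remains open. Also open, going by these compounds, is how the ring would read with hydrogen at both carbons that carry fluoro in compound 2.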